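Replacing the Aryl Group on the Five-Membered Ring

This account rests on a few compounds, and the source may have more. Where it says the series, first, only, none or still open, it means among the compounds named here.

Compound 1, `Cc1ccccc1-n1nc(-c2ccccc2)nc1CNc1ccc(C(=O)NO)cc1`, gives 57.1% in an assay on Sf9 cells for inhibition of protein deacetylase HDAC6 (Homo sapiens), read by fluorescence, with a stated time of 40 min, tested at 100 nM; a higher number here means more inhibition at the concentration tested (going by the name of the read-out), a lower number less inhibition.
Compound 2, `COc1ccc(-n2nc(-c3ccccc3)nc2CNc2ccc(C(=O)NO)cc2)cc1`, gives 63.4% in this assay.
Compound 3, `O=C(NO)c1ccc(NCc2nc(-c3cccc(Cl)c3)nn2-c2ccccc2)cc1`, gives 61.2% in this assay.

All three share the same core and differ only in the aromatic groups attached to it. The number for compound 3 sits between those of compound 1 and compound 2, and the gaps to both lie within the scatter of repeated measurements, so the three compounds cannot be told apart on these figures.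

Compound 4, `O=C(NO)c1ccc(NCc2nc(-c3ccc(C(F)(F)F)cc3)nn2-c2ccccc2)cc1`, has not yet been measured. Its change from compound 3 is 4-(trifluoromethyl)phenyl in place of 3-chlorophenyl on an aromatic carbon. Among the measured compounds shown here, the only step measured so far, a number 6.3 percentage points higher from compound 1 to compound 2 (within the scatter), concerns the group on the aromatic nitrogen and not the group on the aromatic carbon, so it does not bear directly on this change; it does show that swapping one aromatic group for another at a different place left the number essentially unchanged. For the measured compounds named here, no measured step touches the group on the aromatic carbon itself.

With nothing pointing either way, the step from compound 3 to compound 4 is expected to be a number 2.2 percentage points lower from compound 3 to compound 4 (within the scatter), that is, no change beyond the scatter. Compound 4 is therefore estimated at 59%, in a range from 45% to 73%.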

Compound 4, a percentage reported as inhibition, at one concentration (the size of the read-out at that concentration, not a potency): 41.6%
Beside the measured number, compound 4's estimate is 17.4 percentage points above it, outside the stated range (below it).
By their numbers in this assay, from the lowest: compound 4; then compounds 1, 3 and 2 (each within the scatter of the next).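

In this assay, the aromatic group on the carbon between two ring nitrogen atoms turns out to matter: 4-(trifluoromethyl)phenyl in place of 3-chlorophenyl gives a number 19.6 percentage points lower from compound 3 to compound 4 (beyond the scatter). This is the first step shown that clears the scatter, whereas the change on the aromatic nitrogen, a number 6.3 percentage points higher from compound 1 to compound 2 (within the scatter), did not. No measurement shown explains this drop.

The change alters both the group on the phenyl ring and its place there, and a 4-chlorophenyl or a 3-(trifluoromethyl)phenyl group at this carbon would help separate the two. On these data alone, it also remains open how an amine or a carboxylic acid on this phenyl ring would affect the number, and whether other groups at this carbon would give numbers as low as that of compound 4.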